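The source may hold more compounds than are shown below. What is called first, only, known or untested is meant among the compounds shown, and "the series" means these compounds.

Three compounds share one core and differ only in the length of the chain on the oxygen attached to the ring. Compound 1 `CCCCCCCOc1ccc(NC(=O)O/N=C/c2ccccc2)cc1` carries the shortest chain, and in an assay on H4 cells for inhibition of Fatty-acid amide hydrolase 1 (Homo sapiens) (on this read-out lower numbers stand for stronger inhibition and higher numbers for weaker inhibition), compound 1 gives 8.6 nM. Compound 2 `CCCCCCCCCCOc1ccc(NC(=O)O/N=C/c2ccccc2)cc1` gives 0.35 nM, and compound 3 `CCCCCCCCCCCCOc1ccc(NC(=O)O/N=C/c2ccccc2)cc1` gives 2.4 nM. Lengthening the chain brings a 25-fold lower number from compound 1 to compound 2 (1.39 log units; beyond the scatter), while a further extension brings a 6.9-fold higher number from compound 2 to compound 3 (0.84 log units; beyond the scatter); taken across both, a 3.6-fold lower number from compound 1 to compound 3 (0.55 log units; beyond the scatter). Compound 2 therefore stands at the lowest number of the three.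

Compound 4 `CCCCCCCCCCOc1ccc(NC(=O)O/N=C/c2ccc(F)cc2)cc1` keeps the chain of compound 2 and alters a different part of the molecule: fluoro in place of hydrogen on an aromatic carbon. For the measured compounds named here, none of the measured steps touches that ring; all three concern the chain, so nothing measured here bears directly on this change. Going by the values given here, with no step to lean on, the change is expected to stay within the scatter, and the expected step is a 1.1-fold higher number from compound 2 to compound 4 (0.06 log units; within the scatter). Compound 4 is thus estimated to give about 0.4 nM in this assay, within a range from 0.1 nM to 1.5 nM.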

Compound 4, half-maximal inhibitory concentration: 0.25 nM
Compound 4: the middle estimate sits 1.6-fold (0.20 log units) above what was measured; the measured number falls inside the stated range.
By their numbers in this assay, from the lowest: compounds 4 and 2 (each within the scatter of the next); then compound 3; then compound 1.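

For the compounds shown here, the earlier compounds speak only about the chain, and this is the first reading on the phenyl group of the shared core. In this assay, going from phenyl to 4-fluorophenyl brings a 1.4-fold lower number from compound 2 to compound 4 (0.15 log units; within the scatter), so the two compounds cannot be told apart, and this position takes a fluoro in place of hydrogen while the number stays in the sub-nanomolar range set by the best chain. Nothing available here offers an explanation for this result.

Going by these compounds, whether a chloro, a methoxy or an amine at the same place would be taken as well remains open, since a single fluoro says little about other groups. Also open, on these data alone, is whether the fluoro would read the same on the shorter chain of compound 1 or the longer chain of compound 3.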